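From Ethoxymethyl to Acetoxymethyl: the Expected Cytotoxicity Step

The source may hold more compounds than are shown below. What is called first, only, known or untested is meant among the compounds shown, and "the series" means these compounds.

Measured compounds:
compound 1, `CCc1cccc2c(OC)c(-c3occ(C)c3CO)ccc12`: 6.6 ug/mL
compound 2, `CCc1cccc2c(OC)c(-c3occ(C)c3COC)ccc12`: 8.8 ug/mL
compound 3, `CCOCc1c(C)coc1-c1ccc2c(CC)cccc2c1OC`: > 10 ug/mL

In a functional assay on KBVIN cells (Homo sapiens) for cytotoxicity, read by MTT assay, with a stated time of 72 h (a lower number here means that less compound is needed, a higher number that more compound is needed for the effect), compound 1 gives 6.6 ug/mL. Compound 2 gives 8.8 ug/mL in this assay. Compound 3 gives no number in this assay but only a limit, > 10 ug/mL. That is the limit of > 10 ug/mL in this assay, at which 1 of the 3 values shown sits. The three compounds share one core and differ only in what sits on the oxygen on the saturated carbon: hydrogen, methyl, ethyl. The steps among them are all small: a 1.3-fold higher number from compound 1 to compound 2 (0.12 log units; within the scatter); an at least 1.5-fold higher number from compound 1 to compound 3 (0.18 log units; that floor lies within the scatter); an at least 1.1-fold higher number from compound 2 to compound 3 (0.05 log units; that floor lies within the scatter). Going by the values given here, compound 3 therefore stands at the weak end of what was measured, but no measured step separates it from the others beyond the scatter.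

Compound 4, `CCc1cccc2c(OC)c(-c3occ(C)c3COC(C)=O)ccc12`, continues this series at the same place: acetyl in place of ethyl on an oxygen on a saturated carbon. Among the compounds with values here, the steps that bear on it, hydrogen to methyl and methyl to ethyl, were each within the scatter, and the change from ethyl to acetyl is of the same kind and size. A step that the limit leaves unreadable from compound 3 to compound 4 is therefore expected, that is, none beyond the scatter. Compound 4 is expected to give about 12 ug/mL in this assay, with a range from 5 ug/mL to 30 ug/mL, and it may again come out only as a limit.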

Compound 4, concentration for half-maximal effect: > 10 ug/mL
Compound 4 ended at the assay's limit; the forecaster's own chance of this, stated with the estimate: 60%; the middle value does not contradict the limit.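

Compound 4 brings something new to this position: acetyl carries a double bond outside aromatic rings and a hydrogen-bond acceptor that ethyl lacks, yet in this assay compound 4 gives only a limit of the assay, > 10 ug/mL. The steps that can be read are an at least 1.5-fold higher number from compound 1 to compound 4 (0.18 log units; that floor lies within the scatter) and an at least 1.1-fold higher number from compound 2 to compound 4 (0.05 log units; that floor lies within the scatter), and both floors lie within the scatter, so the change to acetyl shows no separation from either of these compounds beyond it. Compound 3 and compound 4 both end at the limit, so the step between them cannot be read: the limit of > 10 ug/mL in this assay, at which 2 of the 4 values shown sit.

On these data alone, what stays open is how far past the limit compound 3 and compound 4 lie, and whether any group at this place would move the number beyond the scatter in either direction. A longer chain such as butyl on the oxygen on a saturated carbon, or an amine or a carboxylic acid in place of the ether and ester groups, would extend the comparison to kinds of group that the compounds shown do not include.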